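Moving a dimethylamino group on a benzyl arm

This account rests on a few compounds, and the source may have more. Where it says the series, first, only, none or still open, it means among the compounds named here.

Of the compounds shown here, three have been measured in an assay on isolated protein for inhibition of Amine oxidase [flavin-containing] A (Homo sapiens), read by fluorescence, with a stated time of 30 min (a lower number here means a stronger inhibitor, a higher number a weaker inhibitor), and a fourth is still to be tested. Compound 1, `CCN(CCCn1sc2cc(OC)c(OC)cc2c1=O)Cc1ccccc1N(C)C`, gives 16600 nM in this assay. Compound 2, `CCN(CCCn1sc2cc(OC)c(OC)cc2c1=O)Cc1ccc(N(C)C)cc1`, differs from compound 1 only in 4-(dimethylamino)phenyl in place of 2-(dimethylamino)phenyl on a saturated chain carbon bound to an amine nitrogen, and in this assay compound 2 gives 11300 nM. This change made a step of a 1.5-fold lower number from compound 1 to compound 2 (0.17 log units; within the scatter), so the two numbers cannot be told apart with confidence.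

Compound 3, `CCN(CCCCCCn1sc2cc(OC)c(OC)cc2c1=O)Cc1ccccc1N(C)C`, carries the same arm as compound 1 but on a different core; the difference between the two cores is not broken down here. In this assay compound 3 gives 3400 nM, the lowest of the three numbers and beyond the scatter from both compound 1 and compound 2.

Compound 4, `CCN(CCCCCCn1sc2cc(OC)c(OC)cc2c1=O)Cc1ccc(N(C)C)cc1`, stands to compound 3 as compound 2 stands to compound 1: it differs by 4-(dimethylamino)phenyl in place of 2-(dimethylamino)phenyl on a saturated chain carbon bound to an amine nitrogen. The place of the change is the same in both pairs, so this is the same change made on the second core. Because the earlier step was a 1.5-fold lower number from compound 1 to compound 2 (0.17 log units; within the scatter), a step of about a 1.5-fold lower number from compound 3 to compound 4 (0.17 log units; within the scatter) is expected here as well. On that basis compound 4 is estimated to give about 2300 nM in this assay, most likely between 1000 nM and 6000 nM.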

Compound 4, half-maximal inhibitory concentration: 7100 nM
The estimate for compound 4 lay 3.1-fold (0.49 log units) below the measured number, and the stated range ends below it.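

In this assay, going from 2-(dimethylamino)benzyl to 4-(dimethylamino)benzyl on the core of compound 3 gives a 2.1-fold higher number from compound 3 to compound 4 (0.32 log units; beyond the scatter), a modest step but one that can be read with confidence. Set beside the earlier pair, this shows that the result of the change on one core did not carry over to the other core in this series, so the first pair was a poor guide to the second: the same change on two cores in this assay, a 1.5-fold lower number (0.17 log units; within the scatter) from compound 1 to compound 2 and a 2.1-fold higher number (0.32 log units; beyond the scatter) from compound 3 to compound 4, 3.1-fold (0.49 log units) apart, beyond the scatter of two such steps. Among the compounds shown here, it does not show why the two cores behave differently, and it offers no rule for other cores, since each core contributes one pair and the pair on the core of compound 1 cannot be told apart, which means only the pair on the core of compound 3 shows a clear preference for one arm.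

The compounds shown leave open whether the gap between the two steps would grow, shrink or vanish on a core with a longer chain leading to the amine nitrogen. They also leave open whether a benzyl arm carrying a methoxy group or a diethylamino group in place of the dimethylamino group would respond to the same move in the same way.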